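Bromo in Place of Nitro: Compound 3 to Compound 4

The compounds below may be only part of what the source reports. "The series", "measured", "known", "first", "only" and "open" are said of these compounds alone.

Measured so far, all in a functional assay on MM1 cells (Homo sapiens) for antiproliferative activity, read by MTT assay, with a stated time of 72 h; a lower number here means a stronger inhibitor, a higher number a weaker inhibitor:
compound 1 `CCC[C@H](NC(=O)/C(C#N)=C/c1ccccc1)c1ccccc1` gives 6250 nM
compound 2 `CCC[C@H](NC(=O)/C(C#N)=C/c1ccc(O)cc1)c1ccccc1` gives > 10000 nM
compound 3 `CCC[C@H](NC(=O)/C(C#N)=C/c1ccc(O)c([N+](=O)[O-])c1)c1ccccc1` gives 8200 nM

The value of compound 2 is a limit of the assay, not a number. Compound 3 has the highest of the two numbers; its nearest neighbour is compound 1, and the gap between them lies within the scatter. The third value shown is a limit (the limit of > 10000 nM in this assay, at which 1 of the 3 values shown sits). Two steps link these compounds: the hydroxy entering gave an at least 1.6-fold higher number from compound 1 to compound 2 (0.20 log units; that floor lies within the scatter), and the nitro entering gave an at least 1.2-fold lower number from compound 2 to compound 3 (0.08 log units; that floor lies within the scatter).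

Compound 4 `CCC[C@H](NC(=O)/C(C#N)=C/c1ccc(O)c(Br)c1)c1ccccc1` differs from compound 3 by bromo in place of nitro on an aromatic carbon. Within the data shown here, the only step that bears on this change is the one in which the nitro entered, and its floor lies within the scatter. So removing the nitro again and putting a bromo in its place is expected to give no step beyond the scatter, a 1.2-fold lower number from compound 3 to compound 4 (0.07 log units; within the scatter). Compound 4 is therefore estimated at 7000 nM, between 3000 nM and 15000 nM, with a real chance that the assay reports only a limit.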

Compound 4, half-maximal inhibitory concentration: > 10000 nM
Compound 4: a limit, no number; the forecaster's own chance of this, stated with the estimate: 30%; middle value at least 1.4-fold (0.15 log units) away from the limit.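

In this assay compound 4 gives > 10000 nM, which is a limit of the assay and not a number. Bromo in place of nitro on this aromatic carbon, ortho to a hydroxy group, gives an at least 1.2-fold higher number from compound 3 to compound 4 (0.08 log units; that floor lies within the scatter), and 3-bromo-4-hydroxyphenyl in place of phenyl gives an at least 1.6-fold higher number from compound 1 to compound 4 (0.20 log units; that floor lies within the scatter), so neither change shows a step beyond the scatter, and a second group at this position leaves that picture as it was. The step between compound 2 and compound 4 cannot be read, because both sit at the same limit: the limit of > 10000 nM in this assay, at which 2 of the 4 values shown sit.

On these data alone, whether an amine or a carboxylic acid on this same carbon would give a step beyond the scatter remains open. Also open, as far as these compounds go, is whether a longer chain elsewhere on the shared core would do so.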